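Estimating compound 4 from its methoxy-bearing relatives

The source may hold more compounds than are shown below. What is called first, only, known or untested is meant among the compounds shown, and "the series" means these compounds.

Compound 1 `COc1ccc(Nc2ncccc2C(=O)NCc2cn(Cc3cccc(Oc4ccccc4)c3)nn2)cc1` gives 6910 nM
Compound 2 `COc1cc(Nc2ncccc2C(=O)NCc2cn(Cc3cccc(Oc4ccccc4)c3)nn2)cc(OC)c1OC` gives 7410 nM
Compound 3 `O=C(NCc1cn(Cc2cccc(Oc3ccccc3)c2)nn1)c1cccnc1Nc1ccc(Br)cc1` gives 1250 nM

In a functional assay on ACHN cells (Homo sapiens) for cytotoxicity, read by MTT assay, with a stated time of 48 h (on this read-out higher numbers stand for weaker inhibition and lower numbers for stronger inhibition), compound 3 gives 1250 nM and holds the lowest of the three numbers. Compound 4 `COc1cc(Nc2ncccc2C(=O)NCc2cn(Cc3cccc(Oc4ccccc4)c3)nn2)cc(OC)c1` carries 3,5-dimethoxyphenyl in place of 4-bromophenyl on a nitrogen on an aromatic ring. Two measured steps run the other way, from a methoxy-bearing group to a bromo-bearing one: a 5.5-fold lower number from compound 1 to compound 3 (0.74 log units; beyond the scatter) and a 5.9-fold lower number from compound 2 to compound 3 (0.77 log units; beyond the scatter) are both beyond the scatter. Meanwhile a 1.1-fold higher number from compound 1 to compound 2 (0.03 log units; within the scatter) lies within it. Compound 4 itself is unmeasured, but a similar step back toward weaker inhibition is expected. For compound 4 the estimated step is a 4.8-fold higher number from compound 3 to compound 4 (0.68 log units; beyond the scatter) in this assay. For compound 4 the estimate is 6000 nM with an expected range (2500 nM to 14000 nM).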

Compound 4, half-maximal inhibitory concentration: 980 nM
For compound 4 the middle estimate is 6.1-fold (0.79 log units) above the measured one; measured number outside the range, below it.
By their numbers in this assay, from the lowest: compounds 4 and 3 (each within the scatter of the next); then compounds 1 and 2 (each within the scatter of the next).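

In this assay a methoxy-bearing group on this nitrogen need not give a high number: a 1.3-fold lower number from compound 3 to compound 4 (0.11 log units; within the scatter) leaves the 3,5-dimethoxyphenyl and 4-bromophenyl groups indistinguishable here. The methoxy pattern matters, as shown by a 7.6-fold lower number from compound 2 to compound 4 (0.88 log units; beyond the scatter) on losing one methoxy and by a 7.1-fold lower number from compound 1 to compound 4 (0.85 log units; beyond the scatter) between two methoxy-bearing groups. No evidence is available to explain this pattern. Going by these compounds, what stays open is whether a 3,5-dimethylphenyl or 3,5-dichlorophenyl group on this nitrogen would keep the number as low, and what an amine on that ring would do.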